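This account rests on a few compounds, and the source may have more. Where it says the series, first, only, none or still open, it means among the compounds named here.

Measured in an ADME assay on a cell-free system (plasma, Rattus norvegicus) for protein binding:
- compound 1 `O=C(Nc1cnc(-n2nccn2)c(Cl)c1)Nc1cnc2cc(Cl)nn2c1C1CC1`: 98.7%
- compound 2 `CO[C@@H](C)c1c(NC(=O)Nc2cnc(-n3nccn3)c(Cl)c2)cnc2cc(Cl)nn12`: 97%
- compound 3 `O=C(Nc1cnc(-n2nccn2)c(Cl)c1)Nc1cnc2cc(Cl)nn2c1C1CCOCC1`: 97.7%

On these numbers, compound 3 cannot be told apart from either of the others. The data show a 1.8-fold higher unbound fraction from compound 1 to compound 3 (0.25 log units; within the scatter) and a 1.3-fold lower unbound fraction from compound 2 to compound 3 (0.12 log units; within the scatter). Among the measured compounds shown here, only one pair separates clearly, with a 2.3-fold higher unbound fraction from compound 1 to compound 2 (0.36 log units; beyond the scatter).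

The next compound is compound 4 `COCc1c(NC(=O)Nc2cnc(-n3nccn3)c(Cl)c2)cnc2cc(Cl)nn12`, where methoxymethyl replaces oxan-4-yl on an aromatic carbon: methoxymethyl in place of oxan-4-yl on an aromatic carbon.

For the measured compounds named here, no measured step makes this exact change, so two steps serve as guides. The closest is a 1.3-fold lower unbound fraction from compound 2 to compound 3 (0.12 log units; within the scatter), which swaps 1-methoxyethyl for oxan-4-yl. Read in reverse, it points gently towards more free compound when the open chain returns, but it stays within the scatter. The step a 2.3-fold higher unbound fraction from compound 1 to compound 2 (0.36 log units; beyond the scatter) also moves towards more free compound, and it is modest. Methoxymethyl is not the same group as 1-methoxyethyl, so compound 2 is only a rough stand-in.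

A small rise in the free fraction is therefore expected in this assay, probably not clearly beyond the scatter. The estimated change is a 1.5-fold higher unbound fraction from compound 3 to compound 4 (0.18 log units; within the scatter). For compound 4 the expected value is 96.5%, with an estimated range from 94% to 98%.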

Compound 4, plasma protein binding: 96.5%
Estimate against measurement, compound 4: no gap at the digits printed; the measured number falls inside the stated range.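

In this assay, the open methoxymethyl chain on this aromatic carbon, with 3 heavy atoms and no ring, can stand in for the six-membered oxan-4-yl ring with 6 heavy atoms without a clear change, giving a 1.5-fold higher unbound fraction from compound 3 to compound 4 (0.18 log units; within the scatter). Taking the methyl off the saturated chain carbon of 1-methoxyethyl also leaves the result within the scatter, with a 1.2-fold higher unbound fraction from compound 2 to compound 4 (0.07 log units; within the scatter), so this methyl, like the ring, is not needed for the free fraction seen with compound 2. Against cyclopropyl the new group does separate, with a 2.7-fold higher unbound fraction from compound 1 to compound 4 (0.43 log units; beyond the scatter), which makes compound 4 the second compound after compound 2 to stand clearly apart from compound 1, while compound 3 does not, and the shift remains modest, with compound 4 still giving 96.5%.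

Nothing in the data gives a reason for these shifts. Still open, from the compounds shown here alone, is whether an amine or a carboxylic acid at this position, or a longer chain such as ethoxyethyl, would free substantially more of the compound than methoxymethyl does.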